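This account rests on a few compounds, and the source may have more. Where it says the series, first, only, none or still open, it means among the compounds named here.

In a functional assay on T-24 cells (Homo sapiens) for cytotoxicity, read by colorimetric assay and MTT assay (on this read-out lower numbers stand for stronger inhibition and higher numbers for weaker inhibition), compound 1 `CCN(CC)C(=O)Cn1c(=O)c(-c2ccc(OC)cc2)cc2c(OC)cc(OC)cc21` gives 10000 nM and compound 2 `COc1ccc(-c2cc3c(OC)cc(OC)cc3n(CC(=O)OCc3ccccc3)c2=O)cc1` gives 10000 nM as well. For the measured compounds named here, compound 2 therefore stands level with compound 1, its nearest measured neighbour, and the series so far shows no spread in this read-out. The next compound is compound 3 `COc1ccc(-c2cc3c(OC)cc(OC)cc3n(CC(=O)O)c2=O)cc1`, which keeps the shared core. Its change from compound 2 is hydrogen in place of benzyl on an oxygen next to a carbonyl group and amounts to hydrogen in place of benzyl on an oxygen next to a carbonyl group, or benzyloxycarbonyl to carboxy. Going by the values given here, the one measured step that bears on this, benzyloxy in place of diethylamino on a carbonyl carbon, shows no change at the digits printed from compound 1 to compound 2 (within the scatter) and so offers no sign of a large effect from exchanging that group. Among the compounds with values here, no measured compound carries the carboxy group, so this support is indirect and rests on a single comparison. The estimate accordingly expects no change at the digits printed from compound 2 to compound 3 (within the scatter) and no step beyond the scatter in this assay for this change. For compound 3 the estimated value is 10000 nM with an expected range from 4000 nM to 25000 nM in repeat measurements.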

Compound 3, half-maximal inhibitory concentration: 10000 nM
For compound 3 middle estimate and measured number coincide at the digits printed, and the stated range covers the measured number.
By their numbers in this assay, from the lowest: compounds 1, 2 and 3 (each within the scatter of the next).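

In this assay, hydrogen in place of benzyl on an oxygen next to a carbonyl group brings no change at the digits printed from compound 2 to compound 3 (within the scatter), so this step, which takes away the benzyl group with its six-membered aromatic ring of carbon only and leaves the carboxy group, does not move the read-out beyond the scatter. Likewise there is no change at the digits printed from compound 1 to compound 3 (within the scatter), which means that three different groups on this carbonyl carbon, diethylamino, benzyloxy and hydroxy, now stand within the scatter of one another, where the earlier pair offered only two. Nothing measured on these compounds offers an explanation for this flat result.

The three compounds differ only in this one place, so they leave open how the read-out responds to any change elsewhere on the shared core. They also leave open whether a primary amine on the carbonyl carbon, or a longer chain in place of carboxymethyl, would separate from these three compounds in this assay.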